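A Branching Change in a Blood-Pressure Series

The source may report more compounds than this note shows. Statements on the series, on what has been measured and on what is new or still open speak of the compounds shown alone.

Of the compounds shown here, three have been measured. Compound 1 `N#CN/C(=N\C1CC1)Nc1cccnc1` gives 20 mg/kg in a functional assay on the whole organism (blood, strain Wistar-Okamoto) with Rattus norvegicus as the target, with a stated time of 5 days; a lower number here means that less compound is needed, a higher number that more compound is needed for the effect. Compound 2 `CC(C)CC(C)/N=C(\NC#N)Nc1ccncc1` gives 35 mg/kg, and compound 3 `CC(C)CC(C)(C)/N=C(\NC#N)Nc1ccncc1` gives 20 mg/kg. Compound 2 has the highest number of the three, though its gaps to compound 1 and to compound 3 both lie within the scatter. Compound 4 `CCC(C)(CC)/N=C(\NC#N)Nc1ccncc1` is not yet measured; it differs from compound 2 in one place: 1-ethyl-1-methylpropyl in place of 1,3-dimethylbutyl on a double-bonded nitrogen. Among the measured compounds shown here, one measured step bears on this, also changing only the group on the double-bonded nitrogen: a 1.8-fold lower number from compound 2 to compound 3 (0.24 log units; within the scatter). Since that step stayed within the scatter, no step beyond the scatter in this assay is expected, perhaps a slightly lower number. Compound 4 is therefore expected to need 22 mg/kg, in the range 10 mg/kg to 45 mg/kg. That estimate amounts to a 1.6-fold lower number from compound 2 to compound 4 (0.20 log units; within the scatter).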

Compound 4, minimum effective dose: 0.5 mg/kg
Estimate against measurement, compound 4: 44-fold (1.64 log units) above, outside the stated range (below it).
By their numbers in this assay, from the lowest: compound 4; then compounds 1, 3 and 2 (each within the scatter of the next).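

At this place on the double-bonded nitrogen, how the carbons are joined can matter greatly: in this assay there is a 70-fold lower number from compound 2 to compound 4 (1.85 log units; beyond the scatter), although 1,3-dimethylbutyl and 1-ethyl-1-methylpropyl both have 6 carbon atoms and no ring. Among the compounds shown here, the earlier change at this place, a 1.8-fold lower number from compound 2 to compound 3 (0.24 log units; within the scatter), gave no hint of a step this large. No measurement available here explains the large step.

Going by these compounds, it remains open whether a longer chain, such as 1,1-diethylbutyl, or a cyclohexyl ring at this place would keep the number this low.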